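The source may hold more compounds than are shown below. What is called first, only, known or untested is meant among the compounds shown, and "the series" means these compounds.

Measured so far in a functional assay on A-375 cells (Homo sapiens) for inhibition, read by CCK-8 assay, with a stated time of 72 h, tested at 2 uM; on this read-out lower numbers stand for less inhibition of growth and higher numbers for more inhibition of growth at the one concentration tested:
compound 1 `COc1ccc(SCc2ccc(/C=C/C(=O)Nc3ccccc3N)cc2)cc1OC`: 46%
compound 2 `Cc1cc(C)cc(SCc2ccc(/C=C/C(=O)Nc3ccccc3N)cc2)c1`: 8.78%
compound 3 `Nc1ccccc1NC(=O)c1ccc(CSc2cccc(F)c2)cc1`: 37.7%

Compound 3 gives 37.7%, which is within the scatter of compound 1 at 46%. Compound 2, at 8.78%, lies lower than both, beyond the scatter.

The next compound to be tested is compound 4 `Nc1ccccc1NC(=O)c1ccc(CSCCc2ccccc2)cc1`, which carries phenethyl in place of 3-fluorophenyl on a sulfur.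

One measured step also swaps the group on a sulfur, although on a different core: a number 37.2 percentage points lower from compound 1 to compound 2 (beyond the scatter). It replaces 3,4-dimethoxyphenyl with 3,5-dimethylphenyl, and it shows that a change at this place can move this assay a long way. For the measured compounds named here, no measured compound carries phenethyl, so the direction of the new step is poorly defined, and only a modest fall is expected, with a wide margin. The expected change is a number 9.7 percentage points lower from compound 3 to compound 4 (within the scatter). For compound 4 the estimated value is 28%, with an expected range from 8% to 48%.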

Compound 4, percent growth inhibition at one concentration: 21.8%
For compound 4 the middle estimate is 6.2 percentage points above the measured one, within the range that was stated.
By their numbers in this assay, from the lowest: compound 2; then compound 4; then compounds 3 and 1 (each within the scatter of the next).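

In this assay, putting phenethyl in place of 3-fluorophenyl on a sulfur gives a number 15.9 percentage points lower from compound 3 to compound 4 (beyond the scatter). For the compounds shown here, earlier, a change of group at this place could be read only on the core of compound 1, so this is the first sign that growth inhibition also responds to it on the core shared by compound 3 and compound 4. Nothing measured here explains the step.

The change removes a fluorine and adds a saturated chain in one move, so the effect of each part remains unresolved. A plain phenyl, a benzyl or a 3-fluorophenethyl group on the sulfur could separate the two, and an amine or a carboxylic acid on the ring would test a different kind of group at this place.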